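Acetyl to methoxycarbonyl on the core of compound 1

A few compounds are considered here, and "the series" means these few. Any claim that something is new, unique, unknown or untested is made for them only; others in the source may bear on it.

Within the data shown here, in a functional assay on HCT-15 cells (Homo sapiens) (on this read-out lower numbers stand for an effect already at smaller amounts and higher numbers for an effect only at larger amounts of compound), compound 1 `COc1cc(C2OC(c3ccc(N(C)C)cc3)=NN2C(C)=O)cc(OC)c1OC` gives 0.033 uM, the lower of the two numbers available so far. Compound 2 `COc1cc(C2OC(c3ccc(N(C)C)cc3)=NN2C(C)=O)cc(OC)c1OC(C)=O` gives 78 uM. Among the measured compounds shown here, the only measured step, a 2400-fold higher number from compound 1 to compound 2 (3.37 log units; beyond the scatter), is large and comes from acetyl in place of methyl on an oxygen on an aromatic ring.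

Compound 3 `COC(=O)N1N=C(c2ccc(N(C)C)cc2)OC1c1cc(OC)c(OC)c(OC)c1` keeps that methoxy group and changes a different place. The difference is methoxy in place of methyl on a carbonyl carbon whose other neighbour is an amide-type nitrogen in a ring, or acetyl to methoxycarbonyl. For the measured compounds named here, no measured step covers this place, so the large step bears on it only indirectly. It shows that a small edit to compound 1 can shift the number far in this assay, which argues for a wide range, but its size is not carried over. A moderate rise is expected, with low confidence in its size. The expected shift is a 3.6-fold higher number from compound 1 to compound 3 (0.56 log units; beyond the scatter). Compound 3 is expected at 0.12 uM, with an estimated range of 0.02 uM to 1.5 uM.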

Compound 3, concentration for half-maximal effect: 40 uM
The estimate for compound 3 lay 330-fold (2.52 log units) below the measured number, outside the stated range (above it).
By their numbers in this assay, from the lowest: compound 1; then compounds 3 and 2 (each within the scatter of the next).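

In this assay the place on the carbonyl carbon, whose other neighbour is the amide-type nitrogen in a ring, proves as open to a large change as the aromatic oxygen: acetyl to methoxycarbonyl gives a 1200-fold higher number from compound 1 to compound 3 (3.08 log units; beyond the scatter) and the number rises far beyond the scatter. Read with a 2400-fold higher number from compound 1 to compound 2 (3.37 log units; beyond the scatter) as the earlier step, this gives two separate places on the core of compound 1 where a single small edit carries a large step, and both steps run towards a higher number, so compound 1 holds the lowest number of the three compounds. Nothing available accounts for the size of either step.

Going by these compounds, whether the step at the carbonyl carbon follows from the entering oxygen itself or from the methoxy group as a whole stays open, and an ethyl or a dimethylamino group at this same place would help to separate the two readings. On these data alone, it also stays open whether any group other than methyl can keep the number near that of compound 1 here, with a hydrogen on the carbonyl carbon as the smallest case to read.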